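The source may hold more compounds than are shown below. What is called first, only, known or untested is meant among the compounds shown, and "the series" means these compounds.

For the measured compounds named here, in a functional assay on the whole organism for inhibition, with Rattus norvegicus as the target (a lower number here means that less compound is needed, a higher number that more compound is needed for the effect), compound 2 (`CCc1ccc(CC(C)(Oc2ccc(C(C)C)cc2)C(=O)O)cc1`) gives 0.1 mg/kg as the only exact number. Compound 1 (`CC(C)c1ccc(OC(C)(Cc2ccc(C(F)(F)F)cc2)C(=O)O)cc1`) gives < 5 mg/kg and this is a limit. Compound 3 (`COc1ccccc1CC(C)(Oc1ccc(C(C)C)cc1)C(=O)O`) gives > 10 mg/kg and this is also a limit. Compound 4 (`CCc1ccc(CC(C)(Oc2ccc(Cc3ccccc3)cc2)C(=O)O)cc1`) departs from compound 2 as follows: benzyl in place of isopropyl on an aromatic carbon with benzyl in place of isopropyl on an aromatic carbon. Neither measured step replaces the isopropyl, so both bear on it only indirectly. Going by the values given here, the first is a step that the limit leaves unreadable from compound 1 to compound 2 and the second is an at least 100-fold higher number from compound 2 to compound 3 (2.00 log units; beyond the scatter) and only this second one shows that a single replacement can move the number far. A moderately higher number is therefore expected in this assay with wide uncertainty. The expected change is a 4.0-fold higher number from compound 2 to compound 4 (0.60 log units; beyond the scatter) in this estimate. Compound 4 is estimated at 0.4 mg/kg with an expected range from 0.05 mg/kg to 3 mg/kg in this assay for now.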

Compound 4, dose for half-maximal effect: 1 mg/kg
For compound 4 the middle estimate is 2.5-fold (0.40 log units) below the measured one, within the range that was stated.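

For the compounds shown here, exchanging isopropyl for benzyl on an aromatic carbon, para to a large group, gives in this assay a 10-fold higher number from compound 2 to compound 4 (1.00 log units; beyond the scatter), the first direct reading at this position. The position therefore responds to the group it carries, although the step is modest and compound 4 still gives an exact number, 1 mg/kg, rather than a limit. No measurement shown gives a reason for this step.

From the compounds shown here alone, how an amine or a longer chain would read at this position remains open. So does whether a single benzyl result speaks for other ring-bearing groups here.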